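This account rests on a few compounds, and the source may have more. Where it says the series, first, only, none or still open, it means among the compounds named here.

In a physicochemical assay for lipophilicity, using the shake flask method, in phosphate buffer, measured as octanol-water partition, with a stated time of 30 min, at pH 7.4 (a lower number here means a more polar compound, a higher number a more lipophilic compound), compound 1 `Cc1nc(CO)ccc1-c1cnc(NCc2c(F)ccc3c2CCO3)c2cn[nH]c(=O)c12` gives 2.4 and compound 2 `CNC(=O)c1cc(-c2cnc(NCc3c(F)ccc4c3CCO4)c3cn[nH]c(=O)c23)n(C)n1` gives 2.1, so the two values lie within the scatter of each other. Compound 3 `CNC(=O)c1ccc(-c2cnc(NCc3c(F)ccc4c3CCO4)c3cn[nH]c(=O)c23)c(C)n1` has not yet been measured. It differs from compound 2 in one place: 2-methyl-6-(methylcarbamoyl)pyridin-3-yl in place of 1-methyl-3-(methylcarbamoyl)-1H-pyrazol-5-yl on an aromatic carbon. Here 2-methyl-6-(methylcarbamoyl)pyridin-3-yl stands in place of 1-methyl-3-(methylcarbamoyl)-1H-pyrazol-5-yl on an aromatic carbon of the shared core. Going by the values given here, only one measured step bears on this exchange: a number 0.30 log units lower from compound 1 to compound 2 (within the scatter). In that step the same 1-methyl-3-(methylcarbamoyl)-1H-pyrazol-5-yl took the place of 6-(hydroxymethyl)-2-methylpyridin-3-yl. Among the compounds with values here, that departing group resembles the one entering compound 3, with hydroxymethyl where compound 3 has methylcarbamoyl. Within the data shown here, the evidence is thin, since no measured compound carries the entering group itself. No step beyond the scatter is therefore expected, and the estimated change is a number 0.30 log units higher from compound 2 to compound 3 (within the scatter). In this assay, compound 3 is expected at 2.4, with an estimated range from 2 to 2.8.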

Compound 3, distribution coefficient: 2.9
For compound 3 the middle estimate is 0.50 log units below the measured one; measured number above the stated range.
By their numbers in this assay, from the lowest: compounds 2 and 1 (each within the scatter of the next); then compound 3.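

In this assay, this position, on an aromatic carbon ortho to a fused ring, proves sensitive to the exchange of substituents: 2-methyl-6-(methylcarbamoyl)pyridin-3-yl in place of 1-methyl-3-(methylcarbamoyl)-1H-pyrazol-5-yl gives a number 0.80 log units higher from compound 2 to compound 3 (beyond the scatter), although the methylcarbamoyl group is present on both sides. With the six-membered ring kept, methylcarbamoyl in place of hydroxymethyl gives a number 0.50 log units higher from compound 1 to compound 3 (beyond the scatter), so the terminal group also matters here, and the closeness of compound 1 and compound 2 does not mean that the position is indifferent to change. Nothing available explains either step.

As far as these compounds go, what remains open is how much of the first step belongs to the ring itself and how much to its methyl group, which a 6-(methylcarbamoyl)pyridin-3-yl group without that methyl, or a 1-methyl-3-(hydroxymethyl)-1H-pyrazol-5-yl group, would help to separate. From the compounds shown here alone, it is also open how the number would move if a carboxylic acid or a primary amine stood where the methylcarbamoyl sits on the six-membered ring.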